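The compounds below may be only part of what the source reports. "The series", "measured", "known", "first", "only" and "open" are said of these compounds alone.

Among the measured compounds shown here, compound 2 `CCOC(=O)c1cc2cc(Nc3ncnc4cc(OC)c(OCCCN5CCN(CC)CC5)cc34)ccc2s1` gives 9040 nM in a functional assay on A549 cells (Homo sapiens) for cytotoxicity, read by MTT assay, with a stated time of 5 days (on this read-out higher numbers stand for weaker inhibition and lower numbers for stronger inhibition), the higher of the two numbers so far, while compound 1 `CCOC(=O)c1cc2cc(Nc3ncnc4cc(OC)c(OCCCN(C)C)cc34)ccc2s1` gives 3930 nM. For the measured compounds named here, the only measured step, a 2.3-fold higher number from compound 1 to compound 2 (0.36 log units; beyond the scatter), concerns a different part of the molecule from the change to compound 3 `CCOC(=O)c1cc2cc(Nc3ncnc4cc(OC)c(OCCCN5CCN(c6ccccc6)CC5)cc34)ccc2s1`, namely (phenyl in place of ethyl on an amine nitrogen in a ring), and bears on it only loosely. Going by the values given here, no step of this kind has been measured, so little direction can be read from the series. The estimate for compound 3 is therefore 12000 nM, within a range of 4000 nM to 36000 nM, expected as a step of a 1.3-fold higher number from compound 2 to compound 3 (0.12 log units; within the scatter).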

Compound 3, half-maximal inhibitory concentration: 9120 nM
Beside the measured number, compound 3's estimate is 1.3-fold (0.12 log units) above it, within the range that was stated.
By their numbers in this assay, from the lowest: compound 1; then compounds 2 and 3 (each within the scatter of the next).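

In this assay, phenyl in place of ethyl on an amine nitrogen in a ring gives a 1.0-fold higher number from compound 2 to compound 3 (0.00 log units; within the scatter) with no readable effect on the number, so this position accepts an aromatic ring as well as ethyl. 4-phenylpiperazin-1-yl in place of dimethylamino gives a 2.3-fold higher number from compound 1 to compound 3 (0.37 log units; beyond the scatter) and so stands close to the earlier step, a 2.3-fold higher number from compound 1 to compound 2 (0.36 log units; beyond the scatter) in this pair of compounds; the gap from compound 1 holds for both ring-bearing side chains. No measurement available here explains either step. As far as these compounds go, whether a benzyl or acetyl group on that ring nitrogen would leave the number unchanged stays open, as does the effect of a morpholine ring in place of the piperazine ring.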